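Swapping the Ring on the Amide Side Chain

The source may hold more compounds than are shown below. What is called first, only, known or untested is meant among the compounds shown, and "the series" means these compounds.

For the measured compounds named here, compound 2 `CC(=O)N1CC(CNC(=O)c2ccncc2Nc2cc(-c3ccc4ccn(C)c4c3)c3nccnc3c2)C1` holds the lower of the two numbers so far in an assay for inhibition of 6-phosphofructo-2-kinase/fructose-2,6-bisphosphatase 3 (Homo sapiens), read by ADP-Glo, with a stated time of 2 h (a higher number here means a weaker inhibitor, a lower number a stronger inhibitor), giving 137 nM, while compound 1 `Cn1cc(CNC(=O)c2ccncc2Nc2cc(-c3ccc4ccn(C)c4c3)c3nccnc3c2)cn1` gives 159 nM, a gap within the scatter. Going by the values given here, the only measured step at this position, a 1.2-fold lower number from compound 1 to compound 2 (0.06 log units; within the scatter), shows that exchanging the ring on the saturated chain carbon bound to an amide-type nitrogen changed little. Compound 3 `CN1CCC(CNC(=O)c2ccncc2Nc2cc(-c3ccc4ccn(C)c4c3)c3nccnc3c2)C1` makes a further exchange there: 1-methylpyrrolidin-3-yl in place of 1-acetylazetidin-3-yl on a saturated chain carbon bound to an amide-type nitrogen. With one comparable step showing no real movement, compound 3 is expected to show a 1.1-fold lower number from compound 2 to compound 3 (0.02 log units; within the scatter), with an estimate of 130 nM and a range from 50 nM to 350 nM.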

Compound 3, half-maximal inhibitory concentration: 74 nM
Compound 3: the middle estimate sits 1.8-fold (0.24 log units) above what was measured; the measured number falls inside the stated range.
By their numbers in this assay, from the lowest: compounds 3, 2 and 1 (each within the scatter of the next, the first and the last beyond it).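

In this assay this position now gives its first step beyond the scatter, a 2.1-fold lower number from compound 1 to compound 3 (0.33 log units; beyond the scatter), when 1-methylpyrrolidin-3-yl replaces 1-methyl-1H-pyrazol-4-yl. The exchange for 1-acetylazetidin-3-yl stays within the scatter, at a 1.9-fold lower number from compound 2 to compound 3 (0.27 log units; within the scatter), so compound 2 and compound 3 cannot be told apart here. No evidence is available to explain either step. From the compounds shown here alone, what a six-membered ring such as 1-methylpiperidin-4-yl, or a carboxylic acid, would do on the same chain carbon remains open.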